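Swapping 4-chlorophenyl for 3-methoxyphenyl on a shared core

The source may hold more compounds than are shown below. What is called first, only, known or untested is meant among the compounds shown, and "the series" means these compounds.

In a functional assay on A549 cells (Homo sapiens) for antiproliferative activity, read by CCK-8 assay, with a stated time of 72 h (a higher number here means a weaker inhibitor, a lower number a stronger inhibitor), compound 1 `Cc1cc(Nc2cc(N3CCN(C)CC3)nc(Nc3ccc([N+](=O)[O-])cc3)n2)n[nH]1` gives 723 nM and compound 2 `Cc1cc(Nc2cc(N3CCN(C)CC3)nc(Nc3ccc(Cl)cc3)n2)n[nH]1` gives 631 nM on the same read-out. Among the compounds with values here, these two values lie within the usual scatter of each other, so compound 2 cannot be separated from compound 1 on the numbers so far. Compound 3 `COc1cccc(Nc2nc(Nc3cc(C)[nH]n3)cc(N3CCN(C)CC3)n2)c1` differs from compound 2 in one place: 3-methoxyphenyl in place of 4-chlorophenyl on a nitrogen on an aromatic ring with 3-methoxyphenyl in place of 4-chlorophenyl on a nitrogen on an aromatic ring. Within the data shown here, with only a 1.1-fold lower number from compound 1 to compound 2 (0.06 log units; within the scatter) to go on, for chloro in place of nitro on an aromatic carbon, no shift beyond the scatter is expected in this assay even though no measured compound carries the 3-methoxyphenyl group. The estimated change is a 1.1-fold higher number from compound 2 to compound 3 (0.05 log units; within the scatter) and it rests on one small comparison. The expected value for compound 3 is 700 nM with an estimated range of 250 nM to 2000 nM as a rough expectation.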

Compound 3, half-maximal inhibitory concentration: 1690 nM
Compound 3: middle estimate off by 2.4-fold (0.38 log units), on the low side; the range from low to high includes it.
By their numbers in this assay, from the lowest: compounds 2 and 1 (each within the scatter of the next); then compound 3.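

The aromatic group on this nitrogen is not freely interchangeable in this assay: 3-methoxyphenyl in place of 4-chlorophenyl gives a 2.7-fold higher number from compound 2 to compound 3 (0.43 log units; beyond the scatter), and the same group in place of 4-nitrophenyl gives a 2.3-fold higher number from compound 1 to compound 3 (0.37 log units; beyond the scatter), both modest but beyond the scatter. Compound 1 and compound 2 lay within the scatter of each other, so they showed no sensitivity to the group at this position, whereas compound 3 shows that the number can move with this change. Nothing measured here explains the shift.

The 3-methoxyphenyl group differs from the other two in both its substituent and that substituent's ring position, so these compounds cannot say which of the two matters. Going by these compounds, how an unsubstituted phenyl, or a phenyl carrying an amine or a carboxylic acid, would compare also remains open.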